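Amide variation on a hydroxy-pyridopyrimidinedione-type scaffold in rat paw edema

This account rests on a few compounds, and the source may have more. Where it says the series, first, only, none or still open, it means among the compounds named here.

Measured compounds:
compound 1 `CCOC(=O)c1c(O)c2cccnc2n(-c2ccccc2)c1=O`: 15.5%
compound 2 `O=C(Nc1ccc([N+](=O)[O-])cc1)c1c(O)c2cccnc2n(-c2ccccc2)c1=O`: -25.8%

In a functional assay on the whole organism for inhibition, with Rattus norvegicus as the target, read by cytopathic effect and paw edema, at a dose of 100 mg/kg by the oral route (a lower number here means less inhibition, a higher number more inhibition at the dose given (going by the name of the read-out)), compound 2 gives -25.8%, the lowest of the two numbers; the step of a number 41.3 percentage points lower from compound 1 to compound 2 (beyond the scatter) is large. Compound 3 `Cc1cnccc1NC(=O)c1c(O)c2cccnc2n(-c2ccccc2)c1=O` differs from compound 2 by 3-methylpyridin-4-yl in place of 4-nitrophenyl on an amide-type nitrogen. Going by the values given here, no measured step touches this position, so the only guide is that compound 2 itself sits at the bottom. Compound 3 is therefore expected to move by a number 15.8 percentage points higher from compound 2 to compound 3 (beyond the scatter), a modest rise near the edge of scatter, and its estimated value is -10%, within -40% to 20%.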

Compound 3, a percentage reported as inhibition, in the whole organism at one dose (the size of the read-out at that dose, not a potency): 8.8%
Compound 3: middle estimate off by 18.8 percentage points, on the low side, and the stated range covers the measured number.
By their numbers in this assay, from the lowest: compound 2; then compounds 3 and 1 (each within the scatter of the next).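

In this assay, the amide-type nitrogen turns out not to lower the read-out by itself: 3-methylpyridin-4-yl in place of 4-nitrophenyl gives a number 34.6 percentage points higher from compound 2 to compound 3 (beyond the scatter), and (3-methylpyridin-4-yl)amino in place of ethoxy on the carbonyl carbon gives a number 6.7 percentage points lower from compound 1 to compound 3 (within the scatter). Among these three compounds, the low number therefore belongs to the 4-nitrophenyl amide alone, not to both amides. Nothing given here accounts for this difference.

The compounds shown leave open whether the methyl group or the ring nitrogen carries the change. An unsubstituted phenyl or pyridin-4-yl on that nitrogen would separate the two.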